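Swapping a propyl for an oxetane on the side chain

The compounds below may be only part of what the source reports. "The series", "measured", "known", "first", "only" and "open" are said of these compounds alone.

Compound 1 `CCCCn1cc(C(=O)C(=O)Nc2ccc(OC)nc2)c2ccccc21` has the lowest number of the two measured compounds in a functional assay on FaDu cells (Homo sapiens) for cytotoxicity, read by MTT assay, with a stated time of 72 h (a lower number here means that less compound is tolerated, a higher number that more compound is tolerated), giving 18 nM. Compound 2 `COCCc1cc(C(=O)C(=O)Nc2ccc(OC(F)(F)F)cc2)c2ccccn12`, of a different shape, gives 758 nM in this assay, a far wider gap than repeat measurements produce. Compound 3 `COc1ccc(NC(=O)C(=O)c2cn(CC3CCO3)c3ccccc23)cn1` has not been measured. It differs from compound 1 in one place: oxetan-2-yl in place of propyl on a saturated chain carbon bound to an aromatic nitrogen. Nothing measured here shows how such a swap moves this read-out, so only a small step, if any, is expected, with a slight lean toward a higher number, a 1.9-fold higher number from compound 1 to compound 3 (0.29 log units; within the scatter). Compound 3 is estimated at 35 nM, between 10 nM and 120 nM.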

Compound 3, concentration lethal to 50% of the cells: 686 nM
Compound 3: middle estimate off by 20-fold (1.29 log units), on the low side, outside the stated range (above it).
By their numbers in this assay, from the lowest: compound 1; then compounds 3 and 2 (each within the scatter of the next).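

On a saturated chain carbon bound to an aromatic nitrogen, the side chain is not a freely exchangeable part of compound 1. Within the data shown here, putting oxetan-2-yl in place of propyl in this assay gives a 38-fold higher number from compound 1 to compound 3 (1.58 log units; beyond the scatter), the first single-place comparison in this set. Nothing measured here accounts for the size of this step.

Still open, on these data alone, is whether the step follows the ring or its oxygen. A cyclobutyl group or a longer chain at the same place could help separate those two possibilities.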